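A Cyano-to-Benzyl Swap Probed for Cytotoxicity

The compounds below may be only part of what the source reports. "The series", "measured", "known", "first", "only" and "open" are said of these compounds alone.

Compound 1 `CCC1(Cc2ccccc2)OS(=O)(=O)C=C1OCC#N` was tested in an ADME assay on HEL cells (Homo sapiens) for cytotoxicity, with a stated time of 3 days (on this read-out lower numbers stand for higher toxicity in this test and higher numbers for lower toxicity in this test), and compound 1 gives > 200000 nM, which is a limit of the assay rather than a number. Compound 2 `CCCC1(Cc2ccccc2)OS(=O)(=O)C=C1OCc1ccccc1` gives 200000 nM in this assay. Compound 3 `CCC1(Cc2ccccc2)OS(=O)(=O)C=C1OCCCCCCc1ccccc1` gives < 200000 nM in this assay, again a limit of the assay. Among the three values shown, compound 1 thus stands at the limit of > 200000 nM in this assay, at which 1 of the 3 values shown sits, while one further value sits at the limit of < 200000 nM in this assay, at which 1 of the 3 values shown sits. Among the compounds with values here, no two measured compounds differ in only one place, so no step size between them is known. Compound 4 `CCC1(Cc2ccccc2)OS(=O)(=O)C=C1OCCc1ccccc1` has not yet been measured. It differs from compound 1 by benzyl in place of cyano on a saturated chain carbon bound to an oxygen on an unsaturated carbon. The step of a number no higher from compound 1 to compound 4 (the limit leaves the size open) is expected to stay within the usual scatter. Compound 4 is estimated at 200000 nM, between 70000 nM and 400000 nM.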

Compound 4, half-maximal cytotoxic concentration: 48000 nM
For compound 4 the middle estimate is 4.2-fold (0.62 log units) above the measured one; the whole stated range lies above it.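

Benzyl in place of cyano on a saturated chain carbon bound to an oxygen on an unsaturated carbon gives, in this assay, an at least 4.1-fold lower number from compound 1 to compound 4 (0.61 log units; beyond the scatter). Within the data shown here, this is the first readable step between compounds that differ in one place, and it shows that a change at this position can move the read-out beyond the scatter. Its true size stays open, as compound 1 holds only a limit of the assay: the limit of > 200000 nM in this assay, at which 1 of the 4 values shown sits.

The compounds shown do not separate the aromatic ring from the added chain length in the change from cyanomethyl to phenethyl. From the compounds shown here alone, whether an amine or a carboxylic acid at this place would also lower the number remains open.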